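Sulfonamide to acetamide on a shared tetrahydronaphthalene-free core

This account rests on a few compounds, and the source may have more. Where it says the series, first, only, none or still open, it means among the compounds named here.

Measured compounds:
compound 1 `O=S(=O)(Nc1cccc2c1CCCC2c1c[nH]cn1)C1CC1`: 537 nM
compound 2 `CCS(=O)(=O)Nc1cccc2c1CCCC2(O)c1c[nH]cn1`: < 10000 nM

Among the measured compounds shown here, in an assay on isolated protein for binding affinity to Alpha-1A adrenergic receptor (Rattus norvegicus), read by radioligand binding (on this read-out higher numbers stand for weaker inhibition and lower numbers for stronger inhibition), compound 1 gives 537 nM, the only full number recorded. For compound 2 this assay returns a limit, < 10000 nM, and no number. For the measured compounds named here, no step between measured compounds is available; the limit of < 10000 nM in this assay, at which 1 of the 2 values shown sits, is the only further evidence. Compound 3 `CC(=O)Nc1cccc2c1CCCC2c1c[nH]cn1` differs from compound 1 by acetyl in place of cyclopropylsulfonyl on a nitrogen on an aromatic ring. The step is expected to be a 2.8-fold higher number from compound 1 to compound 3 (0.45 log units; beyond the scatter), a weakening somewhat beyond the scatter. Compound 3 is therefore estimated at 1500 nM, with a range from 400 nM to 6000 nM.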

Compound 3, inhibition constant: 525 nM
Compound 3: the middle estimate sits 2.9-fold (0.46 log units) above what was measured; the range from low to high includes it.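

In this assay the exchange of cyclopropylsulfonyl for acetyl on a nitrogen on an aromatic ring gives a 1.0-fold lower number from compound 1 to compound 3 (0.01 log units; within the scatter) and so shows that a sulfonyl group is not needed at this position to keep the affinity of compound 1. Neither the three-membered ring nor the sulfur is required there. Nothing shown gives a reason why the two groups read alike. Still open, on these data alone, is how this nitrogen would read as a free amine, or carrying a longer chain such as butanoyl or a urea.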